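Thiophen-2-yl in place of pyridin-4-yl

The compounds below may be only part of what the source reports. "The series", "measured", "known", "first", "only" and "open" are said of these compounds alone.

Three compounds have so far been followed in an ADME assay on a cell-free system (serum) for metabolic stability; a lower number here means that the compound disappears faster, a higher number that the compound lasts longer. Compound 1 `Cc1ccccc1C(=O)Oc1ccc(O)c(C(C)(C)C)c1` gives < 0.25 h, which is a limit of the assay and not a number. Compound 2 `CC(C)(C)c1cc(NC(=O)c2c(Cl)cc(N)cc2Cl)ccc1O` gives > 1 h, again a limit. Placing (pyridin-4-yl)methyl in place of hydrogen on a nitrogen on an aromatic ring of compound 2 leads to compound 3 `CC(C)(C)c1cc(NC(=O)c2c(Cl)cc(NCc3ccncc3)cc2Cl)ccc1O`. Compound 3 gives > 1 h, also a limit. Compound 3 therefore stands at the limit of > 1 h in this assay, at which 2 of the 3 values shown sit.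

The next structure, compound 4 `CC(C)(C)c1cc(NC(=O)c2c(Cl)cc(NCc3cccs3)cc2Cl)ccc1O`, keeps everything except the ring on the chain, with thiophen-2-yl in place of pyridin-4-yl on a saturated chain carbon bound to a nitrogen on an aromatic ring. A six-membered aromatic ring gives way to a five-membered one, and the hetero atom changes from nitrogen to sulfur.

Among the measured compounds shown here, the one measured step at this place is a step that the two limits leave unreadable from compound 2 to compound 3, so it offers no size to carry over. For the measured compounds named here, with that step as the only guide, no shift beyond the usual scatter is expected in this assay. The estimated change is a step that the limit leaves unreadable from compound 3 to compound 4. For compound 4 the expected value is 2 h, with an estimated range from 0.8 h to 5 h, and the reading may well prove to be a limit again.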

Compound 4, half-life: > 1 h
Compound 4: only a limit was reported; the forecaster's own chance of this, stated with the estimate: 85%; the middle value does not contradict the limit.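

In this assay compound 4 gives > 1 h, which is a limit of the assay and not a number. No step among compound 2, compound 3 and compound 4 can be read, because all three sit at the same limit: the limit of > 1 h in this assay, at which 3 of the 4 values shown sit.

How long each of these compounds really lasts, and whether thiophen-2-yl and pyridin-4-yl differ here at all, stays open.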